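A Smaller Group Replaces the Ethoxycarbonyl on the Shared Core

A few compounds are considered here, and "the series" means these few. Any claim that something is new, unique, unknown or untested is made for them only; others in the source may bear on it.

Of the compounds shown here, three sharing one core have been measured in a functional assay for inhibition of nuclear factor NF-kappa-B complex (Homo sapiens); on this read-out lower numbers stand for stronger inhibition and higher numbers for weaker inhibition. Compound 1 `COc1ccc2c(c1)OC(c1cc(OC)c(OC)c(OC)c1)C(CO)=C2` carries a hydroxymethyl on a double-bonded ring carbon; in this assay compound 1 reached only a limit, > 50000 nM. Compound 2 `CCCCNC(=O)C1=Cc2ccc(OC)cc2OC1c1cc(OC)c(OC)c(OC)c1` carries a butylcarbamoyl at that carbon and in this assay compound 2 gives 25500 nM. Compound 3 `CCOC(=O)C1=Cc2ccc(OC)cc2OC1c1cc(OC)c(OC)c(OC)c1` carries an ethoxycarbonyl there, and in this assay compound 3 gives 25000 nM. The steps are an at least 1.9-fold lower number from compound 1 to compound 2 (0.29 log units; that floor lies within the scatter), an at least 2.0-fold lower number from compound 1 to compound 3 (0.30 log units; that floor lies within the scatter) and a 1.0-fold lower number from compound 2 to compound 3 (0.01 log units; within the scatter). Compound 3 thus sits together with compound 2, while compound 1 is known only through a limit (the limit of > 50000 nM in this assay, at which 1 of the 3 values shown sits).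

Compound 4 `COc1ccc2c(c1)OC(c1cc(OC)c(OC)c(OC)c1)C(/C=N/O)=C2` differs from compound 3 in one place: a group of 3 heavy atoms (1 carbon, 1 nitrogen, 1 oxygen; no ring) in place of a group of 5 heavy atoms (3 carbon, 2 oxygen; no ring), on a double-bonded ring carbon. Among the measured compounds shown here, no measured step makes this exact exchange, but the step from compound 1 to compound 3 involved the same ring carbon and stayed near the scatter, and the step from compound 2 to compound 3 showed no change at all. A step of no more than the scatter, if anything toward a weaker number, is therefore expected: a 1.4-fold higher number from compound 3 to compound 4 (0.15 log units; within the scatter). For compound 4 the estimated value in this assay is 35000 nM, between 12000 nM and 100000 nM.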

Compound 4, half-maximal inhibitory concentration: 14100 nM
Beside the measured number, compound 4's estimate is 2.5-fold (0.39 log units) above it, within the range that was stated.
By their numbers in this assay, from the lowest: compounds 4, 3 and 2 (each within the scatter of the next). At a limit, above all of these: compound 1.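

At this double-bonded ring carbon in this assay, the group of 3 heavy atoms cannot be told apart from the larger ethoxycarbonyl (a 1.8-fold lower number from compound 3 to compound 4 (0.25 log units; within the scatter)) or the still larger butylcarbamoyl (a 1.8-fold lower number from compound 2 to compound 4 (0.26 log units; within the scatter)), so across these three compounds the count of heavy atoms does not set the number. Among the compounds shown here, the comparison with the hydroxymethyl compound gives the first step in this set that lies beyond the scatter (an at least 3.5-fold lower number from compound 1 to compound 4 (0.54 log units; beyond the scatter)), showing that two small groups at this carbon need not behave alike, even though the hydroxymethyl group and the entering group differ by little in size. The value of compound 1 is a limit, so this step is a floor and its full size stays unknown: the limit of > 50000 nM in this assay, at which 1 of the 4 values shown sits.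

As far as these compounds go, it remains open whether an amine, a carboxylic acid or a longer chain at this carbon would move the number beyond the scatter of compounds 2, 3 and 4. The shown compounds also cannot tell whether the hydrogen-bond donor of the entering group matters, and a form of that group with a methyl on its oxygen would separate the donor from the rest of the group.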